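From cyclobutyl to cyclopropyl on compound 1

A few compounds are considered here, and "the series" means these few. Any claim that something is new, unique, unknown or untested is made for them only; others in the source may bear on it.

compound 1 `O=C(O)CCn1c(=O)oc2cc(OCC3CCC3)c(Cl)cc21` gives 12 nm/s
compound 2 `O=C(O)CCn1c(=O)oc2cc(Cl)c(Cl)cc21` gives 24 nm/s
compound 3 `C[C@@H](Oc1cc2oc(=O)n(CCC(=O)O)c2cc1Cl)c1cccnn1` gives < 3 nm/s as a limit

In a physicochemical assay for permeability, using PAMPA (a higher number here means that the compound crosses the layer faster, a lower number that the compound crosses the layer more slowly), compound 1 gives 12 nm/s and compound 2 gives 24 nm/s and these two lie within the scatter of each other, so neither ranks above the other. Compound 3 gives < 3 nm/s as a limit of the assay and not a number.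

Compound 4 `O=C(O)CCn1c(=O)oc2cc(OCC3CC3)c(Cl)cc21` keeps the core of compound 1 and carries cyclopropyl in place of cyclobutyl on a saturated chain carbon bound to an oxygen on an aromatic ring.

Two measured steps alter the same part of the molecule. Chloro in place of the whole cyclobutylmethoxy gave a 2.0-fold higher number from compound 1 to compound 2 (0.30 log units; within the scatter) as its result. A larger group holding an aromatic ring with hetero atoms, placed on the same oxygen, gave an at least 4.0-fold lower number from compound 1 to compound 3 (0.60 log units; beyond the scatter) as its result. Compound 4 brings in no such ring. Even compound 2 at 24 nm/s stays within the scatter of compound 1 after losing the whole group, so for the much smaller change in compound 4 no step beyond the scatter is expected in this assay here. The estimated step is a 1.1-fold higher number from compound 1 to compound 4 (0.03 log units; within the scatter) and lies within the scatter. Compound 4 is expected at 13 nm/s with an estimated range of 6 nm/s to 28 nm/s for the measurement.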

Compound 4, apparent permeability: 19 nm/s
Estimate against measurement, compound 4: 1.5-fold (0.16 log units) below, and the stated range covers the measured number.
By their numbers in this assay, from the lowest: compounds 1, 4 and 2 (each within the scatter of the next). At a limit, below all of these: compound 3.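

In this assay, cyclopropyl in place of cyclobutyl on a saturated chain carbon bound to an oxygen on an aromatic ring gives a 1.6-fold higher number from compound 1 to compound 4 (0.20 log units; within the scatter), and cyclopropylmethoxy in place of chloro gives a 1.3-fold lower number from compound 2 to compound 4 (0.10 log units; within the scatter), so compounds 1, 2 and 4 cannot be ranked against one another, and the smaller carbon-only ring makes no readable difference here. Compound 3 gives < 3 nm/s, which is a limit of the assay and not a number: the limit of < 3 nm/s in this assay, at which 1 of the 4 values shown sits. Measured against that limit, the cyclopropyl-bearing group in place of the larger group with its aromatic ring gives an at least 6.3-fold higher number from compound 3 to compound 4 (0.80 log units; beyond the scatter), so compound 3 goes against the otherwise flat picture, and compound 4 now shows that this separation holds for a second carbon-only group on that oxygen.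

On these data alone, what remains open is which feature of the group in compound 3 goes with its limit, and a benzyl group, which has an aromatic ring of carbon only, on the same oxygen would help to separate the ring's nitrogen atoms from its size. As far as these compounds go, it also remains open whether an amine or a longer chain in place of cyclopropyl would stay level with compound 1 in this assay.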